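The compounds below may be only part of what the source reports. "The series", "measured", "known", "first", "only" and "open" are said of these compounds alone.

Series values in a functional assay on RAW264.7 cells (Mus musculus) for inhibition, read by immunoassay, with a stated time of 20 h; a lower number here means a stronger inhibitor, a higher number a weaker inhibitor:
- compound 1 `O=C1OC(O)C(c2ccc(-c3ccc(-c4ccccc4)cc3)cc2)=C1Br`: 3610 nM
- compound 2 `CCCCc1ccc(-c2ccc(C3=C(Br)C(=O)OC3O)cc2)cc1`: 2240 nM
- compound 3 `O=C1OC(O)C(c2cccc(-c3ccc4ccccc4c3)c2)=C1Br`: "not determined" (no result reported)

Going by the values given here, only two numbers are available, and they cannot be separated: a 1.6-fold lower number from compound 1 to compound 2 (0.21 log units; within the scatter). Compound 2 therefore stands level with compound 1, and compound 3 offers no number for comparison.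

The next compound is compound 4 `CCCCc1ccc(C2=C(c3ccc(-c4ccc(CCCC)cc4)cc3)C(O)OC2=O)cc1`. The change is 4-butylphenyl in place of bromo on a double-bonded ring carbon, with the butyl group of compound 2 kept.

Among the compounds with values here, the one measured step, a 1.6-fold lower number from compound 1 to compound 2 (0.21 log units; within the scatter), concerns a different place on the molecule and stayed within the scatter. Within the data shown here, no measured step touches the bromo, so the data give no direction for this change. No shift beyond the scatter is therefore expected in this assay, though the range must stay wide for so large an exchange. The expected change is a 1.0-fold lower number from compound 2 to compound 4 (0.01 log units; within the scatter). Compound 4 is estimated at 2200 nM, with an expected range of 500 nM to 9000 nM.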

Compound 4, half-maximal inhibitory concentration: 4590 nM
Compound 4: the middle estimate sits 2.1-fold (0.32 log units) below what was measured, and the stated range covers the measured number.
By their numbers in this assay, from the lowest: compounds 2, 1 and 4 (each within the scatter of the next, the first and the last beyond it).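

At the double-bonded ring carbon that holds bromo in compound 1 and compound 2, this assay gives a 2.0-fold higher number from compound 2 to compound 4 (0.31 log units; beyond the scatter) as the only step shown at this position. Going by these compounds alone, the step is modest but beyond the scatter, so this is the first change that registers, even though 4-butylphenyl brings 10 heavy atoms and an aromatic ring in place of a single bromine. Inhibition therefore survives without bromo at this carbon, at a modest cost in the number, and nothing available explains that shift.

Still open, going by these compounds, is whether the shift follows from the phenyl ring itself or from its butyl chain, which unsubstituted phenyl or a chloro or methyl group at this carbon would help separate. Also open, on these data alone, is how an amine or a carboxylic acid at the end of that ring would read.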